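This account rests on a few compounds, and the source may have more. Where it says the series, first, only, none or still open, it means among the compounds named here.

Working notes on the series, measured in a functional assay on Bel-7402 cells (Homo sapiens) for inhibition, read by MTT assay, with a stated time of 72 h; on this read-out lower numbers stand for stronger inhibition and higher numbers for weaker inhibition:

- compound 1 `CNC(=O)CCCCCCCn1nc(-c2cnc3[nH]ccc3c2)c2c(N)ncnc21` gives 17400 nM
- compound 2 `Nc1ncnc2c1c(-c1cnc3[nH]ccc3c1)nn2CCCCCC(=O)NO` gives "not determined" (no result reported)
- compound 3 `Nc1nc2cc(-c3nn(CCCCCCCCCC(=O)NO)c4ncnc(N)c34)ccc2o1` gives > 50000 nM

On these data alone, compound 2 has no number in this assay, so its place stays open. Compound 3 gives > 50000 nM, which is a limit of the assay and not a number. The only limit in the set is the limit of > 50000 nM in this assay, at which 1 of the 3 values shown sits, and it belongs to compound 3, not to compound 2. Within the data shown here, the one true number so far is that of compound 1 (17400 nM), which shares the core of compound 2.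

The next compound to be read is compound 4 `Nc1ncnc2c1c(-c1cnc3[nH]ccc3c1)nn2CCCCCCC(=O)NO`, still unmeasured. The change is (hydroxycarbamoyl)methyl in place of hydroxycarbamoyl on a saturated chain carbon, five bonds along the chain from an aromatic nitrogen.

Among the measured compounds shown here, no measured pair in the set shows what such a replacement does, and compound 2 offers no starting number. A step beyond the scatter in this assay is not expected from this single replacement, and no direction can be assigned. The estimate therefore leans on compound 1 (17400 nM), with a wide range.

For compound 4 the expected value is 6000 nM, with an estimated range from 800 nM to 40000 nM.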

Compound 4, half-maximal inhibitory concentration: 30800 nM
Beside the measured number, compound 4's estimate is 5.1-fold (0.71 log units) below it; measured number inside the range.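

Among these compounds, the first readable comparison on this core in this assay is a 1.8-fold higher number from compound 1 to compound 4 (0.25 log units; within the scatter), for hydroxycarbamoyl in place of (methylcarbamoyl)methyl on a saturated chain carbon, six bonds along the chain from an aromatic nitrogen. Among the compounds shown here, at this position the two chain ends are therefore not told apart on this read-out, so this change gives no measurable step in the one pair available. No measured information here bears on a cause for this result.

On these data alone, compound 2 gives no number, so the step to compound 4 cannot be read, and the effect of (hydroxycarbamoyl)methyl in place of hydroxycarbamoyl at this position stays open. Also open, as far as these compounds go, is whether a carboxylic acid or an amine at the end of the chain on the shared core, or a longer chain ending in hydroxycarbamoyl, would move the number beyond the scatter in this assay.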